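Compound 2: chloro in place of trifluoromethyl

The source may hold more compounds than are shown below. What is called first, only, known or untested is meant among the compounds shown, and "the series" means these compounds.

In a functional assay on HCT-116 cells (Homo sapiens) for cytotoxicity, read by MTT assay, with a stated time of 48 h (a higher number here means a weaker inhibitor, a lower number a stronger inhibitor), compound 1 `CNC(=O)c1ccc(Sc2cccc(NC(=S)Nc3ccc(Cl)c(C(F)(F)F)c3)c2)nc1` gives 5180 nM and compound 2 `CNC(=O)c1ccc(Sc2cccc(NC(=S)Nc3ccc(F)c(C(F)(F)F)c3)c2)nc1` gives 18200 nM, the higher of the two numbers. Compound 3 `CNC(=O)c1ccc(Sc2ccc(NC(=S)Nc3ccc(OC(F)(F)F)cc3)cc2)nc1` gives > 100000 nM, which is a limit of the assay and not a number. The next compound is compound 4 `CNC(=O)c1ccc(Sc2cccc(NC(=S)Nc3ccc(F)c(Cl)c3)c2)nc1`, reached through (chloro in place of trifluoromethyl on an aromatic carbon), with chloro in place of trifluoromethyl on an aromatic carbon. Among the compounds with values here, the only measured step, a 3.5-fold higher number from compound 1 to compound 2 (0.55 log units; beyond the scatter), is modest and swaps chloro for fluoro while trifluoromethyl stays, so it offers only a rough guide to size. Within the data shown here, no measured step removes trifluoromethyl. In this assay the expected step is small and upward, a 1.4-fold higher number from compound 2 to compound 4 (0.14 log units; within the scatter). Compound 4 is estimated at 25000 nM, with an expected range of 8000 nM to 75000 nM.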

Compound 4, half-maximal inhibitory concentration: 17300 nM
Beside the measured number, compound 4's estimate is 1.4-fold (0.16 log units) above it; the measured number falls inside the stated range.
By their numbers in this assay, from the lowest: compound 1; then compounds 4 and 2 (each within the scatter of the next). At a limit, above all of these: compound 3.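

Chloro can stand in place of trifluoromethyl at this position in this assay, with the fluoro group kept: a 1.1-fold lower number from compound 2 to compound 4 (0.02 log units; within the scatter). Within the data shown here, this is the first step that removes trifluoromethyl, and the two numbers lie within the scatter. At this level of activity, trifluoromethyl is therefore not needed on this ring.

As far as these compounds go, whether an amine or a nitrile would be tolerated at this position stays open, as does whether chloro can replace trifluoromethyl when chloro also replaces the fluoro group. Weak compounds can be read only up to a ceiling: the limit of > 100000 nM in this assay, at which 1 of the 4 values shown sits.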